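This account rests on a few compounds, and the source may have more. Where it says the series, first, only, none or still open, it means among the compounds named here.

Compound 1 `Cc1nc(C)c([C@H](OC(C)(C)C)C(=O)O)c(N2CCC(C)(C)CC2)c1-c1ccc(OCCc2cc(F)c(F)cc2F)cc1` is the starting point of this comparison. In an ADME assay on microsomes from liver (Homo sapiens) for metabolic stability, read by LC-MS, tested at 0.5 uM (a higher number here means that the compound lasts longer, a lower number that the compound disappears faster), compound 1 reaches a limit of the assay, > 2 h. Compound 2 `Cc1ccc(CCOc2ccc(-c3c(C)nc(C)c([C@H](OC(C)(C)C)C(=O)O)c3N3CCC(C)(C)CC3)cc2)s1` likewise stops at a limit in this assay, giving > 2 h. Compound 3 `Cc1nc(C)c([C@H](OC(C)(C)C)C(=O)O)c(N2CCC(C)(C)CC2)c1-c1ccc(OCCc2cccnc2)cc1` gives a measured number in this assay, 0.367 h. The step from compound 1 to compound 2 is thus a step that the two limits leave unreadable from compound 1 to compound 2, whereas putting in a pyridin-3-yl group gives an at least 5.4-fold lower number from compound 1 to compound 3 (0.73 log units; beyond the scatter) and an at least 5.4-fold lower number from compound 2 to compound 3 (0.73 log units; beyond the scatter). Both limits sit at the limit of > 2 h in this assay, at which 2 of the 3 values shown sit. Compound 4 `Cc1nc(C)c(CCOc2ccc(-c3c(C)nc(C)c([C@H](OC(C)(C)C)C(=O)O)c3N3CCC(C)(C)CC3)cc2)s1` carries 2,4-dimethyl-1,3-thiazol-5-yl in place of 2,4,5-trifluorophenyl on a saturated chain carbon, two bonds along the chain from an oxygen on an aromatic ring. Among the measured compounds shown here, the group entering here is neither the one measured in compound 2 nor the one in compound 3, so a step of an at least 1.5-fold lower number from compound 1 to compound 4 (0.18 log units; that floor lies within the scatter) is expected, with considerable uncertainty. Compound 4 is therefore estimated to give about 1.3 h in this assay, within a range from 0.4 h to 2.5 h.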

Compound 4, half-life: 0.917 h
Compound 4: the middle estimate sits 1.4-fold (0.15 log units) above what was measured; measured number inside the range.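

In this assay, the 2,4-dimethyl-1,3-thiazol-5-yl group gives an at least 2.1-fold lower number from compound 1 to compound 4 (0.33 log units; beyond the scatter) and an at least 2.1-fold lower number from compound 2 to compound 4 (0.33 log units; beyond the scatter). Among the compounds shown, the two rings with a ring nitrogen, in compound 3 and compound 4, fall short of the limit reached by compound 1 and compound 2, which have no such nitrogen. A ring nitrogen does not fix the number, however, as the change of ring gives a 2.5-fold higher number from compound 3 to compound 4 (0.40 log units; beyond the scatter).

From the compounds shown here alone, the full size of the first two steps stays unknown because compound 1 and compound 2 are limits: the limit of > 2 h in this assay, at which 2 of the 4 values shown sit. Whether the two methyl groups matter also stays open, and a plain 1,3-thiazol-5-yl group would test this.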